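A few compounds are considered here, and "the series" means these few. Any claim that something is new, unique, unknown or untested is made for them only; others in the source may bear on it.

Measured compounds in a functional assay on SNB-75 cells (Homo sapiens) for inhibition, read by sulforhodamine B assay, with a stated time of 48 h, tested at 10 uM; a higher number here means a weaker effect of the compound at the concentration tested, a lower number a stronger effect:
compound 1 `O=C(Nc1cccc(-n2cc(-c3ccncc3)c(-c3cc(O)cc(Cl)c3)n2)c1)Nc1ccc(Cl)c(C(F)(F)F)c1`, 24.1%
compound 2 `COc1cc(Cl)cc(-c2nn(-c3cccc(NC(=O)Nc4ccc(Cl)c(C(F)(F)F)c4)c3)cc2-c2ccncc2)c1`, 14.5%

Within the data shown here, compound 2 and compound 1 lie within the scatter of each other; the single measured step, a number 9.6 percentage points lower from compound 1 to compound 2 (within the scatter), is within the scatter. Compound 3 `COc1cc(Cl)cc(-c2nn(-c3cccc(NC(=O)Nc4cccc(C(F)(F)F)c4)c3)cc2-c2ccncc2)c1` differs from compound 2 by hydrogen in place of chloro on an aromatic carbon. No measured step touches this place, so nothing shown bears directly on it; the one step measured concerns another group and was within the scatter. The expected step is therefore a number 17.5 percentage points higher from compound 2 to compound 3 (beyond the scatter), a weakening of uncertain size. Compound 3 is estimated at 32% in this assay, within 10% to 60%.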

Compound 3, a percentage reported as activity, at one concentration (the size of the read-out at that concentration, not a potency): 12.5%
Compound 3: the middle estimate sits 19.5 percentage points above what was measured, within the range that was stated.
By their numbers in this assay, from the lowest: compounds 3, 2 and 1 (each within the scatter of the next, the first and the last beyond it).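

In this assay the step of a number 2 percentage points lower from compound 2 to compound 3 (within the scatter) shows that the read-out at this concentration stays within the scatter when hydrogen replaces chloro on the 4-chloro-3-(trifluoromethyl)phenyl group. In this pair, the chloro ortho to the trifluoromethyl group is therefore not needed for the effect, a point the earlier step on the other aryl group could not address. Nothing available explains this result.

From the compounds shown here alone, whether an amine or a methoxy group at this place would keep the read-out remains open. So does the effect of replacing the trifluoromethyl group itself.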